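From compound 3 to compound 4: one group exchanged

A few compounds are considered here, and "the series" means these few. Any claim that something is new, unique, unknown or untested is made for them only; others in the source may bear on it.

Three related compounds have numbers in a functional assay on A549 cells (Homo sapiens) for antiproliferative activity, read by sulforhodamine B assay, with a stated time of 48 h; a higher number here means a weaker inhibitor, a lower number a stronger inhibitor. Compound 1 (`COc1cccc(/C=C/C(=O)/C=C(O)/C=C/c2cccc(OC)c2OC)c1OC`) gives 11500 nM and compound 2 (`COc1ccc(OC)c(/C=C/C(=O)/C=C(O)/C=C/c2cc(OC)ccc2OC)c1`) gives 16300 nM, two values within the usual scatter of each other. Compound 3 (`COc1cc(C=C(C(=O)/C=C/c2cccc(OC)c2OC)C(=O)/C=C/c2cccc(OC)c2OC)ccc1O`) gives 130 nM. That is the lowest number of the three, which makes compound 3 the strongest inhibitor so far, and its distance from each of the other two lies well beyond the scatter.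

Compound 4 (`COc1cc(OC)c(C=C(C(=O)/C=C/c2cccc(OC)c2OC)C(=O)/C=C/c2cccc(OC)c2OC)c(OC)c1`) keeps most of compound 3 and exchanges one group: 2,4,6-trimethoxyphenyl in place of 4-hydroxy-3-methoxyphenyl on a double-bonded chain carbon bound to a double-bonded chain carbon. In words, 2,4,6-trimethoxyphenyl stands in place of 4-hydroxy-3-methoxyphenyl on a double-bonded chain carbon bound to a double-bonded chain carbon.

Within the data shown here, no measured pair shows what an exchange of this kind does, so any forecast is loose. The rest of compound 4 matches compound 3, so the expectation starts from 130 nM and stays far closer to it than to the values of the other two compounds. The estimated step of a 3.8-fold higher number from compound 3 to compound 4 (0.59 log units; beyond the scatter) points towards a weaker inhibitor, of moderate size and probably beyond the scatter. In this assay the estimate for compound 4 is 500 nM, with an expected range of 100 nM to 3000 nM.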

Compound 4, half-maximal inhibitory concentration: 630 nM
Beside the measured number, compound 4's estimate is 1.3-fold (0.10 log units) below it, and the stated range covers the measured number.
By their numbers in this assay, from the lowest: compound 3; then compound 4; then compounds 1 and 2 (each within the scatter of the next).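

In this assay, among these compounds, the group on a double-bonded chain carbon bound to a double-bonded chain carbon proves to matter: putting 2,4,6-trimethoxyphenyl in place of 4-hydroxy-3-methoxyphenyl gives a 4.8-fold higher number from compound 3 to compound 4 (0.69 log units; beyond the scatter), a weaker inhibitor, and this is the first measured pair that differs in only one place. The exchange removes the hydrogen-bond donor, adds hydrogen-bond acceptors and heavy atoms, and rearranges the groups on the aromatic ring all at once, so this one pair cannot separate these changes. No measured information explains the weakening, so it stands as an observation only.

On these data alone, it remains open whether a simpler group at this place, such as plain phenyl or 4-hydroxyphenyl, would give a number closer to that of compound 3 or to that of compound 4. Also unresolved is how a group with a different kind of atom, such as 4-aminophenyl, or one with a carboxylic acid, would fare at this place.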